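A few compounds are considered here, and "the series" means these few. Any claim that something is new, unique, unknown or untested is made for them only; others in the source may bear on it.

Compound 1 `O=C(N1CCOCC1)n1cc(-c2ccc3cn[nH]c3c2)ccc1=O`; compound 2 `O=c1ccc(-c2ccc3cn[nH]c3c2)cn1Cc1ccccc1`; compound 3 `Nc1n[nH]c2cc(-c3ccc(=O)n(Cc4cccc(F)c4)c3)ccc12`.

Compound 1 reaches only a limit in an assay for inhibition of MAP kinase-interacting serine/threonine-protein kinase 2 (Homo sapiens), read by luminescence and ADP-Glo, with a stated time of 2 h (on this read-out lower numbers stand for stronger inhibition and higher numbers for weaker inhibition), namely > 2000 nM (the limit of > 2000 nM in this assay, at which 1 of the 3 values shown sits). Compound 2 gives 75 nM. Compound 3 gives 5 nM, the lowest of the two numbers, with compound 2 the nearest. Going by the values given here, the one measured step, an at least 26-fold lower number from compound 1 to compound 2 (1.42 log units; beyond the scatter), concerns the group on the ring nitrogen and does not touch the change considered here. Compound 4 `O=c1ccc(-c2ccc3cn[nH]c3c2)cn1Cc1cccc(F)c1` differs from compound 3 by hydrogen in place of amino on an aromatic carbon. Among the compounds with values here, no measured step bears directly on this change; compounds 2 and 3 differ in both the amino group and the fluorine, so their two values only suggest that losing the amino raises the number. Compound 4 is therefore expected to give about 50 nM, between 12 nM and 200 nM, an expected step of a 10-fold higher number from compound 3 to compound 4 (1.00 log units; beyond the scatter).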

Compound 4, half-maximal inhibitory concentration: 38 nM
The estimate for compound 4 lay 1.3-fold (0.12 log units) above the measured number; measured number inside the range.
By their numbers in this assay, from the lowest: compound 3; then compounds 4 and 2 (each within the scatter of the next). At a limit, above all of these: compound 1.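

In this assay the amino group on this aromatic carbon can now be read as a single change: hydrogen in its place gives a 7.6-fold higher number from compound 3 to compound 4 (0.88 log units; beyond the scatter). Fluoro in place of hydrogen, by contrast, gives a 2.0-fold lower number from compound 2 to compound 4 (0.30 log units; within the scatter), so the fluorine shows no effect beyond the scatter. The 3-fluorobenzyl group in place of (morpholin-4-yl)carbonyl gives an at least 52-fold lower number from compound 1 to compound 4 (1.72 log units; beyond the scatter), a step resting on a limit: the limit of > 2000 nM in this assay, at which 1 of the 4 values shown sits.

On these data alone, whether the amino step holds without the fluorine remains open. So does whether a methylamino or acetylamino group at this carbon would match the amino group.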